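The source may report more compounds than this note shows. Statements on the series, on what has been measured and on what is new or still open speak of the compounds shown alone.

Measured so far:
compound 1 `CN(C)c1ccc(C(=O)Nc2cccc(NC(=O)COc3ccc4occc(=O)c4c3)c2)cc1` — > 10000 nM
compound 2 `CC(C)(C)c1ccc(C(=O)Nc2cccc(NC(=O)COc3ccc4c(=O)ccoc4c3)c2)cc1` — 165 nM

Among the measured compounds shown here, in an assay on isolated protein for inhibition of Rho-associated protein kinase 1 (Homo sapiens), read by scintillation counting, radiometric assay and 33P incorporation, with a stated time of 40 min, in the presence of a further agent that is not named here (on this read-out lower numbers stand for stronger inhibition and higher numbers for weaker inhibition), compound 2 gives 165 nM, the only numerical value in the set. Compound 1 in this assay gives > 10000 nM; this is a limit of the assay, not a number, and it sits at the limit of > 10000 nM in this assay, at which 1 of the 2 values shown sits. For the measured compounds named here, no step between two measured compounds can be counted here, so nothing about the size of any change follows from these two compounds alone.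

Compound 3 `NCc1ccc(C(=O)Nc2cccc(NC(=O)COc3ccc4c(=O)ccoc4c3)c2)cc1` has not yet been measured in this assay. It differs from compound 2 by aminomethyl in place of tert-butyl on an aromatic carbon. Going by the values given here, with no measured step to lean on, the expected step from compound 2 to compound 3 in this assay is a 2.4-fold higher number from compound 2 to compound 3 (0.38 log units; beyond the scatter), a modest weakening that may or may not exceed the usual scatter. Compound 3 is estimated at 400 nM, with a range from 80 nM to 3000 nM.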

Compound 3, half-maximal inhibitory concentration: 532 nM
Compound 3: the middle estimate sits 1.3-fold (0.12 log units) below what was measured; low and high end bracket the measured number.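

In this assay, among the compounds shown here, replacing tert-butyl with aminomethyl, para to a large group, gives a 3.2-fold higher number from compound 2 to compound 3 (0.51 log units; beyond the scatter), the first step that can be read. This place therefore accepts a smaller group carrying a nitrogen, with a hydrogen-bond donor and acceptor that tert-butyl lacks, and compound 3 still gives 532 nM. No measured property in hand bears on the reason for this step.

Compound 1 gives > 10000 nM, a limit of the assay, and it differs from the other compounds in more than one place, so steps to it cannot be read. The single exchange changes size and nitrogen content together, and the shown compounds leave open how a carboxylic acid, a dimethylaminomethyl group or a longer aminoethyl chain would read at this place.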